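A Thiophene Exchange on Compound 3

The source may hold more compounds than are shown below. What is called first, only, known or untested is meant among the compounds shown, and "the series" means these compounds.

In a functional assay on cells (Cancer cell lines, Homo sapiens) for inhibition (a lower number here means a stronger inhibitor of growth, a higher number a weaker inhibitor of growth), compound 1 (`Cc1cc(-c2nc3sc(C)cn3c2/C=N/NC(=N)N)c(C)s1`) gives 14100 nM and compound 2 (`Cc1cn2c(/C=N/NC(=N)N)c(-c3ccsc3)nc2s1`) gives 10200 nM while compound 3 (`N=C(N)N/N=C/c1c(-c2cc(Cl)sc2Cl)nc2n1CCS2`) gives 10000 nM and so stands within the scatter of both. Compound 4 (`Cc1cc(-c2nc3n(c2/C=N/NC(=N)N)CCS3)c(C)s1`) differs from compound 3 by 2,5-dimethylthiophen-3-yl in place of 2,5-dichlorothiophen-3-yl on an aromatic carbon with 2,5-dimethylthiophen-3-yl in place of 2,5-dichlorothiophen-3-yl on an aromatic carbon. The nearest measured evidence is a 1.4-fold lower number from compound 1 to compound 2 (0.14 log units; within the scatter) and lies within the scatter. That step sits on another core and removes no chlorine, so it bears on this exchange only loosely. The expected step is a 1.1-fold higher number from compound 3 to compound 4 (0.04 log units; within the scatter) and so no change beyond the scatter is expected in this assay for this pair. Compound 4 is expected at 11000 nM with an estimated range from 5000 nM to 24000 nM in this measurement.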

Compound 4, concentration for 50% growth inhibition: 17400 nM
Estimate against measurement, compound 4: 1.6-fold (0.20 log units) below; the measured number falls inside the stated range.
By their numbers in this assay, from the lowest: compounds 3, 2, 1 and 4 (each within the scatter of the next).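

In this assay, the exchange of 2,5-dichlorothiophen-3-yl for 2,5-dimethylthiophen-3-yl is a 1.7-fold higher number from compound 3 to compound 4 (0.24 log units; within the scatter) and so shows that, on this shared core, either group can stand at this place without a change beyond the scatter. Unlike the earlier step, this one removes both chlorine atoms. No evidence given here bears on this result. The compounds shown leave open whether an amine or a carboxylic acid on this aromatic carbon, in place of the thiophene, would move the number beyond the scatter.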